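Holding the half-life limit from methylamino to isopropylamino

The source may hold more compounds than are shown below. What is called first, only, known or untested is meant among the compounds shown, and "the series" means these compounds.

- compound 1 `CCOC(=O)NC/C=C\CN(C)C[C@H]1O[C@@H](n2c(C)nc3c(N)ncnc32)[C@H](O)[C@@H]1O`: > 1.5 h
- compound 2 `CC(=O)NC/C=C\CN(C)C[C@H]1O[C@@H](n2cnc3c(N)ncnc32)[C@H](O)[C@@H]1O`: > 1.5 h
- compound 3 `CNc1ncnc2c1ncn2[C@@H]1O[C@H](CN(C)C/C=C\CN)[C@@H](O)[C@H]1O`: > 1.5 h

All three compounds were tested in an ADME assay on microsomes from liver (Homo sapiens) for metabolic stability, read by LC-MS, using NADPH, tested at 1 uM; a lower number here means that the compound disappears faster, a higher number that the compound lasts longer. In this test, compound 3 gives > 1.5 h, which is a limit and not a number. Among the measured compounds shown here, the whole record so far reads (the limit of > 1.5 h in this assay, at which 3 of the 3 values shown sit), so no measured half-life separates the compounds, and no step between them has been measured.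

Compound 4 `CC(C)Nc1ncnc2c1ncn2[C@@H]1O[C@H](CN(C)C/C=C\CN)[C@@H](O)[C@H]1O` differs from compound 3 at one place, with isopropyl in place of methyl on a nitrogen on an aromatic ring. Nothing yet measured shows how such a change acts on the half-life. The expectation therefore starts from compound 3 at > 1.5 h and allows for a result that falls short of that limit. The estimated change is a number no higher from compound 3 to compound 4 (the limit leaves the size open), and no shift beyond the usual scatter is expected. Compound 4 is expected at 1.5 h, with an estimated range of 0.7 h to 3 h.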

Compound 4, half-life: > 1.5 h
Compound 4: no number, only a limit (the forecaster's own chance of this, stated with the estimate: 65%); the middle value lies on the limit itself.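

Among the compounds shown here, compound 3 and compound 4 each give a limit and not a number, so no step between them can be read. The compounds shown leave open how long any of them actually lasts and whether isopropyl in place of methyl changes the half-life, since all share one limit: the limit of > 1.5 h in this assay, at which 4 of the 4 values shown sit.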